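This account rests on a few compounds, and the source may have more. Where it says the series, first, only, none or still open, it means among the compounds named here.

Compound 3 `CN(C)C(=O)c1cc2cnc(Nc3ccc(NC(=O)C4(C(=O)Nc5ccc(Br)cc5)CC4)cc3)nc2n1C1CCCC1` gives 94.3% in a functional assay on T47D cells (Homo sapiens) for inhibition, read by CCK-8 assay, with a stated time of 72 h, tested at 10 uM (on this read-out higher numbers stand for more inhibition of growth at the one concentration tested and lower numbers for less inhibition of growth), and stands highest of the three measured numbers; compound 1 `CN(C)C(=O)c1cc2cnc(Nc3ccc(NC(=O)C4(C(=O)Nc5cccc(O)c5)CC4)cc3)nc2n1C1CCCC1` gives 83.7% and compound 2 `CN(C)C(=O)c1cc2cnc(Nc3ccc(NC(=O)C4(C(=O)Nc5ccc(F)cc5)CC4)cc3F)nc2n1C1CCCC1` gives 67.9%. Compound 4 `CN(C)C(=O)c1cc2cnc(Nc3ccc(NC(=O)C4(C(=O)Nc5cccc(Cl)c5)CC4)cc3)nc2n1C1CCCC1` differs from compound 3 in one place: 3-chlorophenyl in place of 4-bromophenyl on an amide-type nitrogen. Among the measured compounds shown here, the only step that touches the same amide-type nitrogen is a number 10.6 percentage points higher from compound 1 to compound 3 (beyond the scatter), where a 4-bromophenyl replaced a 3-hydroxyphenyl. For the measured compounds named here, no measured pair isolates a move from a 4-bromophenyl to a 3-chlorophenyl; compound 2 carries a 4-fluorophenyl together with a second change, so its value alone cannot be assigned. A halogenated phenyl remains, so the expected step of a number 8.3 percentage points lower from compound 3 to compound 4 (within the scatter) is small, within the scatter or slightly downward. Compound 4 is therefore estimated at 86%, with a range of 68% to 97%.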

Compound 4, percent growth inhibition at one concentration: 92.6%
Estimate against measurement, compound 4: 6.6 percentage points below, within the range that was stated.
By their numbers in this assay, from the lowest: compound 2; then compounds 1, 4 and 3 (each within the scatter of the next, the first and the last beyond it).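

On the amide-type nitrogen, a swap of 4-bromophenyl for 3-chlorophenyl changes the halogen and its ring place together, yet in this assay the result is a number 1.7 percentage points lower from compound 3 to compound 4 (within the scatter) and so does not separate the two groups. With the ring place held, chloro in place of hydroxy gives a number 8.9 percentage points higher from compound 1 to compound 4 (within the scatter) and also stays unresolved. No measured property bears on these steps.

A 4-chlorophenyl or 3-bromophenyl would separate halogen identity from ring place. From the compounds shown here alone, an unsubstituted phenyl, a methoxy or an amine on this ring remains open.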